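The compounds below may be only part of what the source reports. "The series", "measured", "known", "first", "only" and "open" are said of these compounds alone.

Measured compounds:
- compound 1, `CCC/N=C(\NC#N)Nc1cc(C(F)(F)F)cc(C(F)(F)F)c1`: 12400 nM
- compound 2, `CC(C)CC/N=C(\NC#N)Nc1cc(C(F)(F)F)cc(C(F)(F)F)c1`: 5600 nM
- compound 3, `CCC/N=C(\NC#N)Nc1cc(Cl)cc(Cl)c1`: 31000 nM

Of the compounds shown here, three have been measured in a functional assay (aorta) with Rattus norvegicus as the target; a higher number here means a weaker inhibitor, a lower number a stronger inhibitor. Compound 1 and compound 2 share one core and differ in a single place: isopropyl in place of methyl on a saturated chain carbon, two bonds along the chain from a double-bonded nitrogen. That change gave a 2.2-fold lower number from compound 1 to compound 2 (0.35 log units; beyond the scatter). Compound 3 carries a different core from compound 1; the difference between the two cores is not broken down here. In this assay compound 3 gives 31000 nM, the highest of the three numbers, and it sits nearer to compound 1 than to compound 2.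

Compound 4, `CC(C)CC/N=C(\NC#N)Nc1cc(Cl)cc(Cl)c1`, has not yet been measured. It stands to compound 3 as compound 2 stands to compound 1, the difference being (isopropyl in place of methyl on a saturated chain carbon, two bonds along the chain from a double-bonded nitrogen). The place of the change is described in the same words for both pairs, so this is the same change made a second time, now on the core of compound 3.

For the measured compounds named here, the expectation for compound 4 rests on the single earlier instance of this change, a 2.2-fold lower number from compound 1 to compound 2 (0.35 log units; beyond the scatter), and on the number for compound 3. Since the change is the same and the two cores gave numbers in the same broad region, a step of about the same size is expected, namely a 2.2-fold lower number from compound 3 to compound 4 (0.35 log units; beyond the scatter). Going by the values given here, with only one prior example, the range is kept wide. Compound 4 is therefore estimated at 14000 nM, with an expected span from 7000 nM to 30000 nM.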

Compound 4, half-maximal inhibitory concentration: 18700 nM
Compound 4: middle estimate off by 1.3-fold (0.13 log units), on the low side; the range from low to high includes it.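

In this assay, putting isopropyl in place of methyl on the core of compound 3 gave a 1.7-fold lower number from compound 3 to compound 4 (0.22 log units; within the scatter), so on this core the step taken alone does not separate the two compounds. Set beside the earlier step on the core of compound 1, it shows no measurable difference in how the change reads on the two cores: the same change on two cores in this assay, a 2.2-fold lower number (0.35 log units; beyond the scatter) from compound 1 to compound 2 and a 1.7-fold lower number (0.22 log units; within the scatter) from compound 3 to compound 4, 1.3-fold (0.13 log units) apart, within the scatter of two such steps. For the compounds shown here, this means the step seen on the first core is compatible with the result on the second, but it rests on only two pairs, one of them within the scatter, and so it does not establish a reliable gain on the core of compound 3 or a constant step on any further core.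

The compounds shown leave open how the numbers in this assay would respond if the chain ended in a cyclohexyl ring, an amine or a hydroxyl group, or were simply a longer chain. They also leave open whether the same change would read alike on a core carrying methoxy or nitro groups in place of the chlorine atoms or trifluoromethyl groups.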